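A few compounds are considered here, and "the series" means these few. Any claim that something is new, unique, unknown or untested is made for them only; others in the source may bear on it.

Measured so far:
compound 1 `CC(C)C[C@H](N)CN(C(=O)[C@@H]1C[C@H]1c1ccccc1)c1ccc(-c2ccccc2)cc1`: 880 nM
compound 2 `CC(C)C[C@@H](N)CN(C(=O)[C@@H]1C[C@H]1c1ccccc1)c1ccc(-c2ccccc2)cc1`: 1.8 nM

Among the compounds with values here, in a functional assay for agonist activity at G protein-coupled receptor 88 (Homo sapiens), read by HTRF and cAMP accumulation (on this read-out lower numbers stand for an effect already at smaller amounts and higher numbers for an effect only at larger amounts of compound), compound 2 gives 1.8 nM, the lowest of the two numbers; the only other compound, compound 1, sits at 880 nM. Within the data shown here, the single measured step, a 490-fold lower number from compound 1 to compound 2 (2.69 log units; beyond the scatter), rests on the fact that compounds 1 and 2 differ only in the configuration as drawn and concerns configuration alone. Compound 3 `CN[C@@H](CC(C)C)CN(C(=O)[C@@H]1C[C@H]1c1ccccc1)c1ccc(-c2ccccc2)cc1` keeps that configuration and changes something else: 3-methyl-1-(methylamino)butyl in place of 1-amino-3-methylbutyl on a saturated chain carbon bound to an amide-type nitrogen. Among the measured compounds shown here, no measured step touches this change, so the estimate leans on compound 2 and allows a modest move in either direction. The step of a 2.8-fold higher number from compound 2 to compound 3 (0.44 log units; beyond the scatter) is the expected outcome. Compound 3 is estimated at 5 nM, within 1.5 nM to 30 nM.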

Compound 3, half-maximal effective concentration: 2 nM
Beside the measured number, compound 3's estimate is 2.5-fold (0.40 log units) above it, within the range that was stated.
By their numbers in this assay, from the lowest: compounds 2 and 3 (each within the scatter of the next); then compound 1.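

The amine nitrogen of this chain accepts the larger 3-methyl-1-(methylamino)butyl group in place of 1-amino-3-methylbutyl without leaving the scatter, with a 1.1-fold higher number from compound 2 to compound 3 (0.05 log units; within the scatter). So a primary amine is not required here for a low number in this assay, since a secondary amine serves as well. The other step into the same compound, a 440-fold lower number from compound 1 to compound 3 (2.64 log units; beyond the scatter), is large, so the starting compound decides what this methyl appears to do.

Still open, from the compounds shown here alone, is how an ethylamino or dimethylamino group would behave at this nitrogen. An acetamide there is equally unresolved.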